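From 1-(4-acetamidophenyl)ethyl to 1-phenylethyl on the amine

The compounds below may be only part of what the source reports. "The series", "measured", "known", "first", "only" and "open" are said of these compounds alone.

In an assay on CHO cells for displacement of a labelled ligand from 5-hydroxytryptamine receptor 1B (Homo sapiens) (on this read-out lower numbers stand for stronger inhibition and higher numbers for weaker inhibition), compound 2 `CC(=O)Nc1ccc([C@@H](C)NCC2CCN(CCCc3c[nH]c4ccc(-n5cnnc5)cc34)CC2)cc1` gives 8.9 nM. Its configurational counterpart compound 1 `CC(=O)Nc1ccc([C@H](C)NCC2CCN(CCCc3c[nH]c4ccc(-n5cnnc5)cc34)CC2)cc1` gives 9.3 nM in this assay. The step of a 1.0-fold lower number from compound 1 to compound 2 (0.02 log units; within the scatter) places the pair within the scatter, so compound 2 stands level with compound 1 and not apart from it. Compound 3 `C[C@H](NCC1CCN(CCCc2c[nH]c3ccc(-n4cnnc4)cc23)CC1)c1ccccc1` differs from compound 2 by 1-phenylethyl in place of 1-(4-acetamidophenyl)ethyl on an amine nitrogen. Within the data shown here, the only measured step concerns configuration alone and bears on no such exchange of groups, so nothing measured here sizes the change. For compound 3 a move toward higher numbers in this assay is expected, a 4.5-fold higher number from compound 2 to compound 3 (0.65 log units; beyond the scatter), with an estimate of 40 nM and a range from 10 nM to 160 nM.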

Compound 3, half-maximal inhibitory concentration: 58 nM
For compound 3 the middle estimate is 1.5-fold (0.16 log units) below the measured one; the measured number falls inside the stated range.
By their numbers in this assay, from the lowest: compounds 2 and 1 (each within the scatter of the next); then compound 3.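

Among these compounds, compound 3 gives the first measure of an exchange of groups at this position: in this assay, 1-phenylethyl in place of 1-(4-acetamidophenyl)ethyl gives a 6.5-fold higher number from compound 2 to compound 3 (0.81 log units; beyond the scatter), and hydrogen in place of acetamido on an aromatic carbon reads as a 6.2-fold higher number from compound 1 to compound 3 (0.79 log units; beyond the scatter). The acetamido group therefore has a measurable bearing on this read-out, whereas the configuration alone had none beyond the scatter in compounds 1 and 2. Nothing available explains this step.

Going by these compounds, it remains open whether a smaller group on that aromatic carbon, such as an amine or a methoxy group, would keep the lower numbers of compounds 1 and 2. On these data alone, whether configuration matters once the acetamido group is gone also remains open.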